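Replacing 1,3-benzoxazol-7-yl with quinazolin-5-yl in compound 1

The source may report more compounds than this note shows. Statements on the series, on what has been measured and on what is new or still open speak of the compounds shown alone.

Within the data shown here, in an ADME assay on microsomes from liver (Rattus norvegicus) for metabolic stability, read by LC-MS, with a stated time of 15 min, tested at 1 uM (a higher number here means that more of the compound is left, a lower number that less of the compound is left), compound 1 `Cc1cc(F)cnc1N1CCN(C(=O)CCCc2cccc3ncoc23)[C@@H](C)C1` gives 0% and so holds the lower of the two numbers so far, while compound 2 `O=C(CCS(=O)(=O)c1cccc2ncsc12)N1CCN(c2ccc(Cl)cn2)CC1` gives 31% and the gap lies beyond the scatter. Compound 3 `Cc1cc(F)cnc1N1CCN(C(=O)CCCc2cccc3ncncc23)[C@@H](C)C1` has not been measured. It carries quinazolin-5-yl in place of 1,3-benzoxazol-7-yl on a saturated chain carbon, three bonds along the chain from a carbonyl carbon and is otherwise unchanged. Among the measured compounds shown here, no measured pair shows what such a swap does. The expected step of a number 6 percentage points higher from compound 1 to compound 3 (within the scatter) is small and upward and may stay within the scatter. Compound 3 is estimated at 6% with a range of 0% to 25% until it is measured.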

Compound 3, percent of the compound remaining: 0%
Estimate against measurement, compound 3: 6 percentage points above; low and high end bracket the measured number.
By their numbers in this assay, from the lowest: compounds 1 and 3 (each within the scatter of the next); then compound 2.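

In this assay, the swap of 1,3-benzoxazol-7-yl for quinazolin-5-yl on a saturated chain carbon, three bonds along the chain from a carbonyl carbon, gives no change at the digits printed from compound 1 to compound 3 (within the scatter). Among these compounds, this is the first direct test of a change at this position, and here replacing one two-ring aromatic group with the other leaves the reading where it was, with nothing gained. Still open, from the compounds shown here alone, is whether an amine or a carboxylic acid in place of quinazolin-5-yl, or a longer chain, would leave more compound behind. No measurement at hand accounts for this result.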